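Series notes: acid in place of tetrazole on the chain

The source may report more compounds than this note shows. Statements on the series, on what has been measured and on what is new or still open speak of the compounds shown alone.

Measured so far:
compound 1 `CC(C)(C)CC[C@H](c1ccc(C(=O)NCc2nn[nH]n2)cc1)N1C(=O)C(c2cccc(C(F)(F)F)c2)=N[C@]12CC[C@@H](C(C)(C)C)CC2`: 13 nM
compound 2 `CC(C)(C)CC[C@H](c1ccc(C(=O)NCCC2=NNNN2)cc1)N1C(=O)C(c2cc(Cl)cc(Cl)c2)=N[C@]12CC[C@@H](C(C)(C)C)CC2`: 65 nM

In an assay on CHO cells for displacement of a labelled ligand from Glucagon receptor (Homo sapiens), read by scintillation counting, with a stated time of 60 min (a higher number here means a weaker inhibitor, a lower number a stronger inhibitor), compound 2 gives the higher of the two numbers; compound 1 gives 13 nM, a gap beyond the scatter. Compound 3 `CC(C)(C)CC[C@H](c1ccc(C(=O)NCCCC(=O)O)cc1)N1C(=O)C(c2cc(Cl)cc(Cl)c2)=N[C@]12CC[C@@H](C(C)(C)C)CC2` has not been measured. Its change from compound 2: a group of 4 heavy atoms (2 carbon, 2 oxygen; no ring) in place of a group of 5 heavy atoms (1 carbon, 4 nitrogen; one five-membered non-aromatic ring with 4 hetero atoms), on a saturated chain carbon, two bonds along the chain from an amide-type nitrogen. Among the measured compounds shown here, no measured pair isolates this change, so the step is not anchored by data. The swap is expected to cost little: the estimated step of a 1.3-fold lower number from compound 2 to compound 3 (0.11 log units; within the scatter) lies within the scatter. Compound 3 is thus expected near 50 nM, with a range of 15 nM to 200 nM.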

Compound 3, half-maximal inhibitory concentration: 270 nM
The estimate for compound 3 lay 5.4-fold (0.73 log units) below the measured number, and the stated range ends below it.
By their numbers in this assay, from the lowest: compound 1; then compound 2; then compound 3.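

In this assay, among the compounds shown here, carboxymethyl in place of the five-membered non-aromatic ring with 4 hetero atoms, on a saturated chain carbon, two bonds along the chain from an amide-type nitrogen, gives a 4.2-fold higher number from compound 2 to compound 3 (0.62 log units; beyond the scatter), the first step that isolates one place. The two groups are therefore not interchangeable at this position. Nothing available bears on the reason for this loss.

On these data alone, whether an amine or a primary amide is tolerated at this place remains open. As far as these compounds go, the effect of chain length alone also remains open, since compound 1 and compound 2 differ in more than one place.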